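The compounds below may be only part of what the source reports. "The series", "measured", "known", "first", "only" and "open" are said of these compounds alone.

The shared core carries a dithiocarbamate chain, and two compounds have been tested in a functional assay on MCF7 cells (Homo sapiens) for antiproliferative activity, read by MTT assay, with a stated time of 72 h; on this read-out lower numbers stand for stronger inhibition and higher numbers for weaker inhibition. Compound 1 `O=c1cc(CSC(=S)N2CCCCC2)oc2ccccc12` gives > 25000 nM, which is a limit of the assay rather than a measured number. Among the compounds with values here, compound 2 `O=c1c(Cl)c(CSC(=S)N2CCCCC2)oc2ccccc12` gives 1000 nM; this is the only real number among the two values, the other sitting at the limit of > 25000 nM in this assay, at which 1 of the 2 values shown sits. The step of an at least 25-fold lower number from compound 1 to compound 2 (1.39 log units; beyond the scatter) is large and lies beyond the scatter.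

Compound 3 `CC(C)N(C(=S)SCc1oc2ccccc2c(=O)c1Cl)C(C)C` differs from compound 2 by diisopropylamino in place of piperidin-1-yl on a thiocarbonyl carbon, which is a change at the amine end of the chain rather than on the aromatic ring. Within the data shown here, the one measured step concerns a different place on the molecule, so it gives no direct guidance on this exchange of amines. Compound 3 is therefore expected to stay close to compound 2, with an estimated step of a 1.2-fold higher number from compound 2 to compound 3 (0.08 log units; within the scatter). The estimate for compound 3 is 1200 nM, with a range from 400 nM to 4000 nM.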

Compound 3, half-maximal inhibitory concentration: > 40000 nM
Compound 3 ended at the assay's limit; the forecaster's own chance of this, stated with the estimate: 10%; middle value at least 33-fold (1.52 log units) from the limit.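

The earlier step concerned only the chloro on the aromatic carbon, whereas this one shows that the amine end of the chain also matters: in this assay, the exchange on the thiocarbonyl carbon gives an at least 40-fold higher number from compound 2 to compound 3 (1.60 log units; beyond the scatter). For compound 3 there is no real number, only a limit: the limit of > 40000 nM in this assay, at which 1 of the 3 values shown sits. The chloro alone is therefore not enough for a measured value here, since compound 3 carries it too, and among the amines shown, only the piperidin-1-yl of compound 2 goes with one.

This single exchange removes the ring and also brings in branched isopropyl groups, so it cannot tell which of these differences goes with the loss. A straight-chain diethylamino group and a pyrrolidine ring at the same place would help to separate the two.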